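Aryl swap on the pyrrolidine of compound 1

The compounds below may be only part of what the source reports. "The series", "measured", "known", "first", "only" and "open" are said of these compounds alone.

Compound 1 `Cc1cccc([C@@H]2CN(C(C)C)C[C@H]2C(=O)N2CCN(c3c(F)cccc3[C@@H](NC(=O)CCN(C)C)C(C)C)CC2)c1` is the weaker of the two compounds measured in an assay on HEK293 cells for displacement of a labelled ligand from Melanocortin receptor 4 (Homo sapiens) (a lower number here means a stronger inhibitor, a higher number a weaker inhibitor), where compound 1 gives 470 nM. Compound 2 `Cc1ccc(N2CCN(C(=O)[C@@H]3CNC[C@H]3c3ccc(Cl)cc3)CC2)c([C@@H](NC(=O)CCN(C)C)C(C)C)c1` differs from compound 1 in several places, and in this assay compound 2 gives 7.2 nM. Compound 3 `CC(C)[C@H](NC(=O)CCN(C)C)c1cccc(F)c1N1CCN(C(=O)[C@@H]2CN(C(C)C)C[C@H]2c2ccc(C(F)(F)F)cc2F)CC1` carries 2-fluoro-4-(trifluoromethyl)phenyl in place of 3-methylphenyl on a saturated ring carbon. Within the data shown here, no single-change step covers this exchange, so the expectation rests on the overall spread of the series: a moderate gain, beyond the scatter, is expected from compound 1 to compound 3, as a 3.9-fold lower number from compound 1 to compound 3 (0.59 log units; beyond the scatter). Compound 3 is estimated at 120 nM, with a range from 30 nM to 450 nM.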

Compound 3, inhibition constant: 61 nM
Estimate against measurement, compound 3: 2.0-fold (0.29 log units) above, and the stated range covers the measured number.
By their numbers in this assay, from the lowest: compound 2; then compound 3; then compound 1.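

Among these compounds, exchanging 3-methylphenyl for 2-fluoro-4-(trifluoromethyl)phenyl on this saturated ring carbon gives a 7.7-fold lower number from compound 1 to compound 3 (0.89 log units; beyond the scatter) in this assay, the first single-place reading at this position. The position therefore responds to the aryl group and accepts the larger substituent, with 11 heavy atoms entering where 7 leave. No available data bear on the reason for this step.

Going by these compounds, the ring fluorine and the trifluoromethyl group enter together, so their separate contributions remain open. Also open, on these data alone, is how a nitrile or methoxy group in place of trifluoromethyl would read.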